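The source may report more compounds than this note shows. Statements on the series, on what has been measured and on what is new or still open speak of the compounds shown alone.

Measured compounds in an in vitro functional assay on HEK285-7 cells for antagonist activity at prostaglandin D2 receptor 2 (Homo sapiens), read by BRET and beta-arrestin recruitment; on this read-out lower numbers stand for stronger inhibition and higher numbers for weaker inhibition:
compound 1 `Nc1nc(-c2ccc(Cl)cc2)c(CC(=O)O)s1`: > 100000 nM, a limit of the assay.
compound 2 `CCC(c1ccccc1)c1nc(-c2ccc(Cl)cc2)c(CC(=O)O)s1`: > 100000 nM, a limit of the assay.
compound 3 `O=C(O)Cc1sc(C(c2ccc(F)cc2)c2ccc(F)cc2)nc1-c1ccnc(N2CCC2)c1`: > 100000 nM, a limit of the assay.

Compound 3 sits at the limit of > 100000 nM in this assay, at which 3 of the 3 values shown sit. Among the measured compounds shown here, no step between measured compounds can be computed, so nothing in these numbers separates compound 3 from the other two; all three are limits and not values. Compound 4 `NS(=O)(=O)c1ccc(-c2nc(C(c3ccc(F)cc3)c3ccc(F)cc3)sc2CC(=O)O)cc1` differs from compound 3 in one place: 4-sulfamoylphenyl in place of 2-(azetidin-1-yl)pyridin-4-yl on an aromatic carbon. With every measured compound at the limit, the step of a number no higher from compound 3 to compound 4 (the limit leaves the size open) in this assay is expected to show no change beyond the scatter, and the likeliest outcome for compound 4 is once more a limit rather than a number. Compound 4 is estimated at 100000 nM, within 20000 nM to 300000 nM.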

Compound 4, half-maximal inhibitory concentration: > 100000 nM
Compound 4: no number, only a limit; the forecaster's own chance of this, stated with the estimate: 80%; the middle value lies on the limit itself.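

Among the compounds shown here, compound 3 and compound 4 both stand as limits, so no step between them can be read: the limit of > 100000 nM in this assay, at which 4 of the 4 values shown sit. The compounds shown leave open which change to the shared core, if any, would give a measurable inhibition value.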